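Shortening the hydroxycarbamoyl chain of compound 2

The source may report more compounds than this note shows. Statements on the series, on what has been measured and on what is new or still open speak of the compounds shown alone.

Two compounds have numbers in a functional assay on SW-620 cells (Homo sapiens) for cytotoxicity (on this read-out lower numbers stand for stronger inhibition and higher numbers for weaker inhibition), so far. Compound 1 (`Cc1ccc2nc(NC(=O)CCCCC(=O)NO)sc2c1`) stands at 4.69 ug/mL and compound 2 (`O=C(CCCCCCC(=O)Nc1nc2ccc([N+](=O)[O-])cc2s1)NO`) at 0.29 ug/mL as the lower of the two numbers, with the gap between them beyond the scatter. Within the data shown here, these two compounds differ in more than one place, so no single-change step is available to size the next move. Compound 3 (`O=C(CCCCC(=O)Nc1nc2ccc([N+](=O)[O-])cc2s1)NO`) has hydroxycarbamoyl in place of 2-(hydroxycarbamoyl)ethyl on a saturated chain carbon, four bonds along the chain from a carbonyl carbon relative to compound 2. Among the measured compounds shown here, a rise in the number in this assay is expected, beyond the scatter, with compound 1 at 4.69 ug/mL as the only higher value at hand. The expected size is a 4.1-fold higher number from compound 2 to compound 3 (0.62 log units; beyond the scatter) as a rough estimate. For compound 3 the estimated value is 1.2 ug/mL with an expected range from 0.3 ug/mL to 4.5 ug/mL in this read-out.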

Compound 3, half-maximal inhibitory concentration: > 30 ug/mL
Compound 3: no number, only a limit (the forecaster's own chance of this, stated with the estimate: 3%); middle value at least 25-fold (1.39 log units) away from the limit.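

Compound 3 carries no number in this assay, only a limit of the assay: the limit of > 30 ug/mL in this assay, at which 1 of the 3 values shown sits.

Hydroxycarbamoyl in place of 2-(hydroxycarbamoyl)ethyl on a saturated chain carbon, four bonds along the chain from a carbonyl carbon, gives an at least 100-fold higher number from compound 2 to compound 3 (2.01 log units; beyond the scatter), so with nitro held constant, chain length alone has a large effect on this read-out. Nitro in place of methyl on an aromatic carbon, with the shorter chain held constant, gives an at least 6.3-fold higher number from compound 1 to compound 3 (0.80 log units; beyond the scatter), so nitro does not by itself confer the low number of compound 2.

From the compounds shown here alone, the true size of both steps stays open, as does whether the loss sets in gradually or abruptly at chain lengths between those of compound 2 and compound 3. Also open, going by these compounds, are the effect of a longer chain and of an amine in place of nitro.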